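Replacing methoxy with methyl on the amide aryl ring

The source may hold more compounds than are shown below. What is called first, only, known or untested is meant among the compounds shown, and "the series" means these compounds.

Of the compounds shown here, two of a shared core have been measured in an assay on isolated protein for inhibition of RAC-alpha serine/threonine-protein kinase (Homo sapiens), read by fluorescence, with a stated time of 30 min, tested at 10 uM; a lower number here means less inhibition, a higher number more inhibition at the concentration tested (going by the name of the read-out). Compound 1 `O=C(Nc1cc(Sc2ncn[nH]2)c(O)c2ccccc12)c1ccc([N+](=O)[O-])cc1` gives 37.3%, and compound 2 `COc1ccc(C(=O)Nc2cc(Sc3ncn[nH]3)c(O)c3ccccc23)cc1` gives 30.8%; the step of a number 6.5 percentage points lower from compound 1 to compound 2 (within the scatter) lies within the scatter, so compound 2 stands no lower than compound 1 in any meaningful sense. Compound 3 `Cc1cccc(C(=O)Nc2cc(Sc3ncn[nH]3)c(O)c3ccccc23)c1` differs from compound 2 by 3-methylphenyl in place of 4-methoxyphenyl on a carbonyl carbon. Within the data shown here, the one measured step also changed this aryl ring and was small, so no step beyond the scatter is expected here. Compound 3 is estimated at 28% in this assay, within 14% to 42%, an expected step of a number 2.8 percentage points lower from compound 2 to compound 3 (within the scatter).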

Compound 3, a percentage reported as inhibition, at one concentration (the size of the read-out at that concentration, not a potency): 20.2%
For compound 3 the middle estimate is 7.8 percentage points above the measured one, within the range that was stated.
By their numbers in this assay, from the lowest: compound 3; then compounds 2 and 1 (each within the scatter of the next).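

In this assay, the aryl group on the carbonyl carbon now gives a number 10.6 percentage points lower from compound 2 to compound 3 (beyond the scatter) and a number 17.1 percentage points lower from compound 1 to compound 3 (beyond the scatter) as steps beyond the scatter, which the step between the first two compounds did not show. This position therefore responds to a change of aryl group, although 3-methylphenyl differs from both earlier groups in the substituent and in its place on the ring. Nothing available explains these lower numbers.

Whether the methyl group itself or its ring position accounts for the steps remains open. So does how 4-methylphenyl, or an aryl ring carrying an amine or a carboxylic acid, would read here.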